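This account rests on a few compounds, and the source may have more. Where it says the series, first, only, none or still open, it means among the compounds named here.

In an ADME assay on BJ cells (Homo sapiens) for cytotoxicity, with a stated time of 72 h (a lower number here means that less compound is needed, a higher number that more compound is needed for the effect), compound 1 `CCN(CC)C(=O)COc1cc2c(-n3nc(-c4ccccn4)nc3N)ncnc2cc1OC` gives only a limit, > 25000 nM. Compound 2 `CCOC(=O)NCCCOc1cc2c(-n3nc(-c4ccccn4)nc3N)ncnc2cc1OC` also gives only a limit, > 11000 nM, so its place on this scale is not a true number. Compound 3 `COc1cc2ncnc(-n3nc(-c4ccccn4)nc3N)c2cc1OCCCNC(=O)OCC(F)(F)F` differs from compound 2 by one small change: trifluoromethyl in place of methyl on a saturated chain carbon bound to an oxygen next to a carbonyl group. This puts trifluoromethyl in place of methyl on a saturated chain carbon bound to an oxygen next to a carbonyl group, turning ethyl into 2,2,2-trifluoroethyl. For the measured compounds named here, the only measured step, a step that the two limits leave unreadable from compound 1 to compound 2, involves a different change and has no readable size, so it offers no guide to size or direction. The sole anchor is therefore the limit of compound 2, > 11000 nM. The expected result is no step beyond the scatter: a step that the limit leaves unreadable from compound 2 to compound 3. For compound 3 the estimate is 15000 nM, with an expected range from 6000 nM to 30000 nM, and another limit would be no surprise.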

Compound 3, half-maximal effective concentration: > 11000 nM
Compound 3: a limit, no number; the forecaster's own chance of this, stated with the estimate: 75%; the middle value does not contradict the limit.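

For the compounds shown here, compound 1, compound 2 and compound 3 each give only a limit, and no step among them can be read. In this assay, as far as these compounds go, the true values of all three stay open, and so does whether trifluoromethyl in place of methyl shifts the read-out at all.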